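Alkynyl phenoxyacetic acids: sulfone variation toward a sulfonamide

This account rests on a few compounds, and the source may have more. Where it says the series, first, only, none or still open, it means among the compounds named here.

Measured so far:
- compound 1, `O=C(O)COc1ccc(Cl)cc1C#Cc1ccc(CO)cc1F`: 28 nM
- compound 2, `CCS(=O)(=O)c1ccc(C)c(C#Cc2cc(Cl)ccc2OCC(=O)O)c1`: 8.6 nM
- compound 3, `O=C(O)COc1ccc(Cl)cc1C#Cc1ccc2c(c1)S(=O)(=O)CC2`: 23 nM

In an assay on CHO cells for displacement of a labelled ligand from prostaglandin D2 receptor 2 (Homo sapiens), read by scintillation counting (on this read-out lower numbers stand for stronger inhibition and higher numbers for weaker inhibition), compound 2 gives the lowest number of the three; its gaps to compound 3 and to compound 1 both lie beyond the scatter, so compound 2 is the most potent of the measured set.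

Compound 4, `Cc1ccc(S(=O)(=O)N(C)CCN(C)C)cc1C#Cc1cc(Cl)ccc1OCC(=O)O`, differs from compound 2 only at the sulfonyl sulfur: (2-(dimethylamino)ethyl)(methyl)amino in place of ethyl on a sulfonyl sulfur. Among the compounds with values here, no measured pair in the set isolates a change of this kind, so the step from compound 2 is open. A modest loss is expected, near the edge of the scatter, since the other sulfonyl-bearing compound 3 also sits above compound 2. The step of a 2.3-fold higher number from compound 2 to compound 4 (0.37 log units; beyond the scatter) is the estimate. Compound 4 is expected at 20 nM, in the range 6 nM to 70 nM.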

Compound 4, inhibition constant: 369 nM
Compound 4: middle estimate off by 18-fold (1.27 log units), on the low side; the whole stated range lies below it.
By their numbers in this assay, from the lowest: compound 2; then compounds 3 and 1 (each within the scatter of the next); then compound 4.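

Within the data shown here, this is the first single-place step: in this assay, (2-(dimethylamino)ethyl)(methyl)amino in place of ethyl on a sulfonyl sulfur gives a 43-fold higher number from compound 2 to compound 4 (1.63 log units; beyond the scatter) and marks this position as sensitive to the change. The sulfonyl sulfur therefore does not accept every larger substituent without a large loss. Nothing available accounts for the size of this step.

The step changes the link to the sulfur and the chain together, so their shares remain unresolved. A plain dimethylamino on the sulfonyl sulfur, or a chain ending in a hydroxyl group, would separate them.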